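Chain Length and Terminal Ring Swap in Cytotoxicity

The source may report more compounds than this note shows. Statements on the series, on what has been measured and on what is new or still open speak of the compounds shown alone.

Compound 1 `c1ccc(OCCCOc2cccc(-c3cc4ccc(C5=NCCN5)cc4o3)c2)cc1`: 10100 nM
Compound 2 `c1ccc(OCCCCOc2cccc(-c3cc4ccc(C5=NCCN5)cc4o3)c2)cc1`: 5800 nM
Compound 3 `N=C(N)c1ccc2cc(-c3cccc(OCCCCCOc4ccccc4)c3)oc2c1`: 4100 nM

These three compounds share a core and have been tested in an ADME assay on L6 cells (Rattus norvegicus) for cytotoxicity, read by resazurin assay, with a stated time of 70 h; on this read-out higher numbers stand for weaker inhibition and lower numbers for stronger inhibition. For the measured compounds named here, the only single-point step among them is a 1.7-fold lower number from compound 1 to compound 2 (0.24 log units; within the scatter), a lengthening of the chain between the two aryl ethers. Compound 3 gives the lowest number of the three in this assay: against compound 1 its number is beyond the scatter lower, but against compound 2 the two values lie within the scatter of each other, so no order between compound 2 and compound 3 can be claimed.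

Compound 4 `c1ccc(OCCCCCOc2cccc(-c3cc4ccc(C5=NCCN5)cc4o3)c2)cc1` is the next compound to be measured. It differs from compound 3 in one place: a group of 5 heavy atoms (3 carbon, 2 nitrogen; one five-membered non-aromatic ring with 2 hetero atoms) in place of a group of 3 heavy atoms (1 carbon, 2 nitrogen; no ring), on an aromatic carbon. Going by the values given here, no measured step bears directly on this exchange. Compounds 2 and 3 differ both in this group and in the chain, and their values sit within the scatter, which gives no sign that the group matters much. Among the compounds with values here, the single direct step, a 1.7-fold lower number from compound 1 to compound 2 (0.24 log units; within the scatter), was itself within the scatter.

Compound 4 is therefore expected to show a step of a 1.1-fold higher number from compound 3 to compound 4 (0.04 log units; within the scatter), with no change beyond the scatter. The estimate for compound 4 in this assay is 4500 nM, in a range from 2000 nM to 10000 nM.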

Compound 4, half-maximal inhibitory concentration: 3700 nM
Beside the measured number, compound 4's estimate is 1.2-fold (0.09 log units) above it, within the range that was stated.
By their numbers in this assay, from the lowest: compounds 4, 3, 2 and 1 (each within the scatter of the next, the first and the last beyond it).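

With the chain held the same, the exchange of the open group of 3 heavy atoms for the five-membered non-aromatic ring with 2 hetero atoms can now be read on its own in this assay: a 1.1-fold lower number from compound 3 to compound 4 (0.04 log units; within the scatter), so the two groups cannot be told apart at this aromatic carbon. The compounds carrying the ring group now also form a series of three chain lengths, in which a 1.7-fold lower number from compound 1 to compound 2 (0.24 log units; within the scatter) and a 1.6-fold lower number from compound 2 to compound 4 (0.20 log units; within the scatter) each stay within the scatter, while the two ends, a 2.7-fold lower number from compound 1 to compound 4 (0.44 log units; beyond the scatter), show a modest change that the earlier single step could not show. No measurement is available that would explain these numbers.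

As far as these compounds go, whether a longer chain would carry the lower numbers further in this assay remains open, as does the effect of placing an amine or a carboxylic acid on the same aromatic carbon. From the compounds shown here alone, it is also open whether the two groups compared here would remain indistinguishable on any read-out other than this one.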